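The compounds below may be only part of what the source reports. "The series", "measured", "known", "first", "only" and "open" are said of these compounds alone.

In a functional assay on A549 cells (Homo sapiens) for cytotoxicity, read by MTT assay, with a stated time of 2 days (a higher number here means a weaker inhibitor, a lower number a stronger inhibitor), compound 1 `CC(=O)OC[C@H]1O[C@H](O[C@]2(COC(C)=O)O[C@H](CO)[C@@H](O)[C@@H]2OC(=O)/C=C/c2ccc(O)cc2)[C@H](O)[C@@H](OC(C)=O)[C@@H]1O` gives 2560 nM and compound 2 `CC(=O)OC[C@H]1O[C@H](O[C@]2(COC(C)=O)O[C@H](CO)[C@@H](O)[C@@H]2OC(=O)/C=C/c2ccc(O)cc2)[C@H](OC(C)=O)[C@@H](O)[C@@H]1O` gives 3200 nM. Among the compounds with values here, these two values lie within the usual scatter of each other, so compound 2 stands level with the only other measured compound. Compound 3 `CC(=O)OC[C@H]1O[C@H](O[C@]2(COC(C)=O)O[C@H](CO)[C@@H](O)[C@@H]2OC(=O)/C=C/c2ccc(O)c(O)c2)[C@H](OC(C)=O)[C@@H](O)[C@@H]1O` departs from compound 2 by one change, hydroxy in place of hydrogen on an aromatic carbon, ortho to a hydroxy group, which turns 4-hydroxyphenyl into 3,4-dihydroxyphenyl. Within the data shown here, no measured pair shows the effect of this change, so the expectation starts from compound 2 at 3200 nM. A small step towards a lower number is expected in this assay, one that may not clear the scatter. The expected step is a 1.5-fold lower number from compound 2 to compound 3 (0.16 log units; within the scatter). For compound 3 the estimated value is 2200 nM, with an expected range from 800 nM to 6000 nM.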

Compound 3, half-maximal inhibitory concentration: 450 nM
For compound 3 the middle estimate is 4.9-fold (0.69 log units) above the measured one; measured number below the stated range.
By their numbers in this assay, from the lowest: compound 3; then compounds 1 and 2 (each within the scatter of the next).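

In this assay, placing a hydroxy on the aromatic carbon ortho to the existing hydroxy group gives a 7.1-fold lower number from compound 2 to compound 3 (0.85 log units; beyond the scatter), a step beyond the scatter. Compound 1 and compound 2 left the aromatic ring untouched and so could not show that this position matters. Here, the move from 4-hydroxyphenyl to 3,4-dihydroxyphenyl alone changes the number clearly, with the rest of the molecule held the same.

The compounds shown leave open whether a methoxy, an amine or a fluorine at this position would do the same as hydroxy, and whether the change would carry over to the acetyl arrangement of compound 1. The reason for the step also stays open, as no measurement given here bears on it.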